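The compounds below may be only part of what the source reports. "The series", "measured", "known", "first", "only" and "open" are said of these compounds alone.

Compound 1 `Cc1cc(C#N)cc(C)c1Oc1ccnc(S(=O)(=O)CC(=O)Nc2ccccc2F)n1` carries the shared core with a 2-fluorophenyl on an amide-type nitrogen. Within the data shown here, in an ADME assay on MT4 cells (Homo sapiens) for cytotoxicity, read by MTT assay, with a stated time of 4 days (on this read-out higher numbers stand for lower toxicity in this test and lower numbers for higher toxicity in this test), compound 1 gives 28400 nM, the highest of the three numbers measured so far. Compound 2 `Cc1cc(C#N)cc(C)c1Oc1ccnc(S(=O)(=O)CC(=O)Nc2ccc(Cl)c(Cl)c2)n1` gives 11700 nM in this assay, and compound 3 `Cc1cc(C#N)cc(C)c1Oc1ccnc(S(=O)(=O)CC(=O)Nc2ccc(Br)cc2)n1` gives 15600 nM. Two measured steps start from compound 1: the step of a 2.4-fold lower number from compound 1 to compound 2 (0.39 log units; beyond the scatter) and the step of a 1.8-fold lower number from compound 1 to compound 3 (0.26 log units; within the scatter). Between the other two compounds the step is a 1.3-fold higher number from compound 2 to compound 3 (0.12 log units; within the scatter). Both changes of the group on the amide-type nitrogen thus moved the number downward from compound 1, one beyond the scatter and one within it.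

Compound 4 `Cc1cc(C#N)cc(C)c1Oc1ccnc(S(=O)(=O)CC(=O)Nc2cccc([N+](=O)[O-])c2)n1` is not yet measured. Its difference from compound 1 is 3-nitrophenyl in place of 2-fluorophenyl on an amide-type nitrogen. The two steps that bear on this change swap out the same 2-fluorophenyl and lower the number by a modest amount each time. Given the steps of a 2.4-fold lower number from compound 1 to compound 2 (0.39 log units; beyond the scatter) and a 1.8-fold lower number from compound 1 to compound 3 (0.26 log units; within the scatter), compound 4 is expected to show a small lowering, a 1.6-fold lower number from compound 1 to compound 4 (0.20 log units; within the scatter), near the edge of the scatter. Compound 4 is therefore estimated at 18000 nM in this assay, within a range from 8000 nM to 40000 nM.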

Compound 4, half-maximal cytotoxic concentration: 23600 nM
The estimate for compound 4 lay 1.3-fold (0.12 log units) below the measured number; the measured number falls inside the stated range.
By their numbers in this assay, from the lowest: compounds 2, 3, 4 and 1 (each within the scatter of the next, the first and the last beyond it).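

In this assay, among these compounds, the 3-nitrophenyl group adds something the earlier compounds lacked: compound 1, compound 2 and compound 3 carry only fluorine, chlorine or bromine on the phenyl ring, whereas this group has no halogen and counts 2 hydrogen-bond acceptors, yet its number stays close to theirs. The three new steps are a 1.2-fold lower number from compound 1 to compound 4 (0.08 log units; within the scatter) and a 1.5-fold higher number from compound 3 to compound 4 (0.18 log units; within the scatter) and a 2.0-fold higher number from compound 2 to compound 4 (0.30 log units; within the scatter) and so leave compound 4 inseparable from each of the others on this read-out. The gap between compound 1 and compound 2 therefore remains the only one among these four compounds that lies beyond the scatter.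

From the compounds shown here alone, all four compounds keep a substituted phenyl ring on the amide-type nitrogen, so it stays open how the number would respond to an amine or a carboxylic acid on that ring, or to a longer chain in place of the ring. Nothing available here gives a reason why these numbers lie so close together.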